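Sulfanyl to aminomethyl exchange on two amide series

The compounds below may be only part of what the source reports. "The series", "measured", "known", "first", "only" and "open" are said of these compounds alone.

Compound 1 `O=C(CCCCCCCCCCS)Nc1cn(-c2ccccc2)nc1-c1ccccc1` and compound 2 `NCCCCCCCCCCCC(=O)Nc1cn(-c2ccccc2)nc1-c1ccccc1` share one core; compound 3 `Cn1cc(NC(=O)CCCCCCCCCCS)c(-c2ccccn2)n1` and compound 4 `Cn1cc(NC(=O)CCCCCCCCCCCN)c(-c2ccccn2)n1` share another, and the difference between the two cores is not broken down here. In a functional assay on U-87MG ATCC cells (Homo sapiens) for cytotoxicity, read by MTT assay, with a stated time of 24 h (a higher number here means a weaker inhibitor, a lower number a stronger inhibitor), compound 1 gives 90000 nM and compound 2 gives 77000 nM. The change between them is aminomethyl in place of sulfanyl on a saturated chain carbon, ten or more bonds along the chain from a carbonyl carbon, and the step it made is a 1.2-fold lower number from compound 1 to compound 2 (0.07 log units; within the scatter). Compound 3 reaches only the limit of this assay, > 150000 nM, which is a limit and not a number (the limit of > 150000 nM in this assay, at which 1 of the 3 values shown sits). Compound 4 carries the same change on the other core: aminomethyl in place of sulfanyl on a saturated chain carbon, ten or more bonds along the chain from a carbonyl carbon. Since a 1.2-fold lower number from compound 1 to compound 2 (0.07 log units; within the scatter) stayed within the scatter, the estimated step is a step that the limit leaves unreadable from compound 3 to compound 4. Compound 4 is therefore estimated at 200000 nM, from 100000 nM to 400000 nM, with a limit again likely.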

Compound 4, half-maximal inhibitory concentration: 90000 nM
Estimate against measurement, compound 4: 2.2-fold (0.35 log units) above, outside the stated range (below it).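

In this assay, aminomethyl in place of sulfanyl on the core of compound 3 gives an at least 1.6-fold lower number from compound 3 to compound 4 (0.22 log units; that floor lies within the scatter). The result is compatible with the change carrying over from one core to the other, but does not establish that it does: the same change on two cores in this assay, a 1.2-fold lower number (0.07 log units; within the scatter) from compound 1 to compound 2 and an at least 1.6-fold lower number (0.22 log units; that floor lies within the scatter) from compound 3 to compound 4; the limit leaves it open whether they differ. Compound 3 stands at > 150000 nM, which is a limit and not a number.

On these data alone, the true size of the step on the core of compound 3 remains open, as does any difference from the step on the core of compound 1. Also open, as far as these compounds go, is how a carboxylic acid or a hydroxyl group in place of sulfanyl, or a shorter chain, would read on either core in this assay.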